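Moving the fluorine on the pendant phenyl ring

A few compounds are considered here, and "the series" means these few. Any claim that something is new, unique, unknown or untested is made for them only; others in the source may bear on it.

Compound 3 `CC1CCN(C2CCN(S(=O)(=O)c3cccc(-c4ccccc4F)c3)CC2)CC1` stands level with compound 1 `CC1CCN(C2CCN(S(=O)(=O)c3cccc(-c4ccccc4C(F)(F)F)c3)CC2)CC1` at the top of the three numbers in a functional assay on DLD-1 cells (Homo sapiens) for antiproliferative activity, read by CellTiter-Glo, with a stated time of 72 h; a higher number here means a weaker inhibitor, a lower number a stronger inhibitor: compound 3 gives 10 nM, compound 1 gives 10 nM, and the step is no change at the digits printed from compound 1 to compound 3 (within the scatter). Compound 2 `CC1CCN(C2CCN(S(=O)(=O)c3cccc(Br)c3)CC2)CC1` gives 3.2 nM, the lowest number of the three, so that a 3.1-fold higher number from compound 2 to compound 3 (0.49 log units; beyond the scatter).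

Compound 4 `CC1CCN(C2CCN(S(=O)(=O)c3cccc(-c4ccc(F)cc4)c3)CC2)CC1` differs from compound 3 by 4-fluorophenyl in place of 2-fluorophenyl on an aromatic carbon. Among the measured compounds shown here, two measured steps bear on this. The step of no change at the digits printed from compound 1 to compound 3 (within the scatter) shows that changing the substituent on the pendant phenyl, trifluoromethyl to fluoro, left the number unchanged. The step of a 3.1-fold higher number from compound 2 to compound 3 (0.49 log units; beyond the scatter) shows that putting the 2-fluorophenyl in place of bromo cost a modest amount. For the measured compounds named here, no measured step moves a substituent from one carbon of the pendant phenyl to another, so the data give no direct guide for this change.

Given that no change at the digits printed from compound 1 to compound 3 (within the scatter) was within the scatter, the pendant phenyl is expected to tolerate this rearrangement of its fluorine as well, and the expected step is no change at the digits printed from compound 3 to compound 4 (within the scatter), no change beyond the scatter. Compound 4 is therefore estimated at 10 nM, with a range of 4 nM to 25 nM.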

Compound 4, half-maximal inhibitory concentration: 12 nM
The estimate for compound 4 lay 1.2-fold (0.08 log units) below the measured number; low and high end bracket the measured number.
By their numbers in this assay, from the lowest: compound 2; then compounds 1, 3 and 4 (each within the scatter of the next).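

In this assay, the only step shown that moves the fluorine around the pendant phenyl is a 1.2-fold higher number from compound 3 to compound 4 (0.08 log units; within the scatter), so 2-fluorophenyl and 4-fluorophenyl cannot be told apart at this aromatic carbon, and 4-fluorophenyl also stands within the scatter of 2-(trifluoromethyl)phenyl at a 1.2-fold higher number from compound 1 to compound 4 (0.08 log units; within the scatter). The gap to bromo persists with the fluorine in its new place, at a 3.8-fold higher number from compound 2 to compound 4 (0.57 log units; beyond the scatter), so all three phenyl-bearing compounds now sit apart from compound 2 as one group, whichever of these substituents the pendant ring carries. No measurement is available that would explain these numbers.

From the compounds shown here alone, what remains open is whether the flat response on the pendant phenyl extends beyond fluoro and trifluoromethyl, for instance to a ring carrying an amine, a carboxylic acid or a methoxy group. Going by these compounds, it is equally open whether the gap between bromo and the phenyl groups reflects something particular to bromo, which chloro, a nitrile or a short alkyl chain on the same aromatic carbon could help to settle.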